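A few compounds are considered here, and "the series" means these few. Any claim that something is new, unique, unknown or untested is made for them only; others in the source may bear on it.

Of the compounds shown here, three built on one shared core have been tested. Compound 1 `O=C1N=C(N2CCC[C@H]2C(=O)Nc2ccc3ncnc(Nc4cccc(Cl)c4)c3c2)S/C1=C/c1cccnc1` carries a pyridin-3-yl group on the double-bonded chain carbon bound to a double-bonded ring carbon; in a functional assay on HepG2 cells (Homo sapiens) for antiproliferative activity, read by MTT assay (a higher number here means a weaker inhibitor, a lower number a stronger inhibitor), compound 1 gives 8500 nM. Compound 2 `O=C1N=C(N2CCC[C@H]2C(=O)Nc2ccc3ncnc(Nc4cccc(Cl)c4)c3c2)S/C1=C/c1ccc2ccccc2n1` carries quinolin-2-yl there and gives 22900 nM, a shift of a 2.7-fold higher number from compound 1 to compound 2 (0.43 log units; beyond the scatter). Compound 3 `O=C1N=C(N2CCC[C@H]2C(=O)Nc2ccc3ncnc(Nc4cccc(Cl)c4)c3c2)S/C1=C/c1ccccc1Br` carries 2-bromophenyl and gives 24300 nM, the highest of the three numbers: against compound 1 it shows a 2.9-fold higher number from compound 1 to compound 3 (0.46 log units; beyond the scatter), while against compound 2 it shows a 1.1-fold higher number from compound 2 to compound 3 (0.03 log units; within the scatter), so those two are not separated.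

Compound 4 `O=C1N=C(N2CCC[C@H]2C(=O)Nc2ccc3ncnc(Nc4cccc(Cl)c4)c3c2)S/C1=C/c1ccccc1Cl` differs from compound 3 only by chloro in place of bromo on an aromatic carbon. For the measured compounds named here, none of the measured steps tests this kind of swap; each of them replaces the whole aryl group, and the two halogen-free steps say nothing about one halogen against another. Exchanging bromo for chloro on the same ring carbon is a small change, so no step beyond the scatter is expected. Compound 4 is therefore estimated at 24000 nM, with a range from 11000 nM to 50000 nM. This estimate amounts to a 1.0-fold lower number from compound 3 to compound 4 (0.01 log units; within the scatter), a step expected to stay within the scatter.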

Compound 4, half-maximal inhibitory concentration: 28100 nM
For compound 4 the middle estimate is 1.2-fold (0.07 log units) below the measured one; the range from low to high includes it.
By their numbers in this assay, from the lowest: compound 1; then compounds 2, 3 and 4 (each within the scatter of the next).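

In this assay, the step of a 1.2-fold higher number from compound 3 to compound 4 (0.06 log units; within the scatter) shows that chloro and bromo on this aromatic carbon are not separated, so the change of halogen does not move the number beyond the scatter. For the compounds shown here, the 2-chlorophenyl group is also not separated from quinolin-2-yl, with a 1.2-fold higher number from compound 2 to compound 4 (0.09 log units; within the scatter) as the step, while pyridin-3-yl remains the one group set apart, with a 3.3-fold higher number from compound 1 to compound 4 (0.52 log units; beyond the scatter) as the step, making compound 1 the strongest inhibitor of the four. Nothing available explains why the pyridin-3-yl compound stands apart from the other three.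

As far as these compounds go, whether fluoro or methoxy on this aromatic carbon would give a number like those of chloro and bromo remains open. It is also unknown whether a plain phenyl ring, or a pyridin-3-yl ring carrying an amine, would match or improve on compound 1.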